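Cyclobutyloxy ester variant of the shared core

The source may report more compounds than this note shows. Statements on the series, on what has been measured and on what is new or still open speak of the compounds shown alone.

Compound 2 `CC1=C(C(=O)C2CC2)C(c2ccsc2)NC(=O)N1` gives 2% in an assay on membranes from CHO cells for displacement of a labelled ligand from adenosine receptor A1 (Homo sapiens), read by scintillation counting, with a stated time of 60 min, tested at 1 uM (on this read-out higher numbers stand for more inhibition at the one concentration tested (going by the name of the read-out) and lower numbers for less inhibition), and compound 1 `CC1=C(C(=O)C2CC2)C(c2ccoc2)NC(=O)N1` gives 1%, the two within the usual scatter. For the measured compounds named here, the single measured step, a number 1 percentage points higher from compound 1 to compound 2 (within the scatter), concerns the aromatic ring and not the carbonyl substituent. Compound 3 `CC1=C(C(=O)OC2CCC2)C(c2ccsc2)NC(=O)N1` differs from compound 2 by cyclobutyloxy in place of cyclopropyl on a carbonyl carbon. Going by the values given here, no measured step touches the carbonyl substituent, so nothing seen sizes this change. Both numbers seen are small, and compound 3 is expected to stay there, with the step of a number 1 percentage points higher from compound 2 to compound 3 (within the scatter) expected to lie within the scatter. Compound 3 is estimated at 3%, range 0% to 15%.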

Compound 3, a percentage reported as inhibition, at one concentration (the size of the read-out at that concentration, not a potency): 40%
The estimate for compound 3 lay 37 percentage points below the measured number; the measured number lies above the stated range.
By their numbers in this assay, from the lowest: compounds 1 and 2 (each within the scatter of the next); then compound 3.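

For the compounds shown here, the carbonyl substituent is the first place where this assay responds clearly: cyclobutyloxy in place of cyclopropyl gives a number 38 percentage points higher from compound 2 to compound 3 (beyond the scatter), whereas the change in the aromatic ring gave only a number 1 percentage points higher from compound 1 to compound 2 (within the scatter). This single step combines the entering oxygen with a four-membered ring replacing a three-membered one. No available measurement bears on why the number rises.

Cyclopropyloxy on the same carbonyl carbon would separate these two changes, and a longer chain such as butyloxy would test the need for a ring. As far as these compounds go, whether furan-3-yl supports the same rise with cyclobutyloxy also remains open.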